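The compounds below may be only part of what the source reports. "The series", "measured", "known", "first", "only" and "open" are said of these compounds alone.

In a functional assay on A549 cells (Homo sapiens) for cytotoxicity, read by MTT assay, with a stated time of 72 h (a lower number here means a stronger inhibitor, a higher number a weaker inhibitor), compound 1 `N#Cc1ccc(/C=C/C(=O)Nc2cc3c(Nc4ccc(F)c(Cl)c4)ncnc3cc2O[C@H]2CCOC2)cc1` is reported as "not active" (no number reported), with no number. On the same core, compound 2 `COc1ccc(OC)c(/C=C/C(=O)Nc2cc3c(Nc4ccc(F)c(Cl)c4)ncnc3cc2O[C@H]2CCOC2)c1` gives 7300 nM and compound 3 `COc1ccc(/C=C/C(=O)Nc2cc3c(Nc4ccc(F)c(Cl)c4)ncnc3cc2O[C@H]2CCOC2)c(OC)c1OC` gives 70 nM, which is the lower of the two numbers. Compound 4 `COc1cc(/C=C/C(=O)Nc2cc3c(Nc4ccc(F)c(Cl)c4)ncnc3cc2O[C@H]2CCOC2)cc(OC)c1O` has not yet been measured. It departs from compound 3 by 4-hydroxy-3,5-dimethoxyphenyl in place of 2,3,4-trimethoxyphenyl on a double-bonded chain carbon bound to a double-bonded chain carbon: 4-hydroxy-3,5-dimethoxyphenyl in place of 2,3,4-trimethoxyphenyl, on a double-bonded chain carbon bound to a double-bonded chain carbon.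

Within the data shown here, only one measured step bears on this change. It alters the same group, and a 100-fold lower number from compound 2 to compound 3 (2.02 log units; beyond the scatter) is large and beyond the scatter. Among the measured compounds shown here, this shows that the number can respond strongly to the pattern on this group, but no measured pair tests a hydroxy group. Neither other compound matches compound 3 at 70 nM, so a move away from it is expected to raise the number, though by less than the measured step. The expected change is an 11-fold higher number from compound 3 to compound 4 (1.06 log units; beyond the scatter). For compound 4 the estimated value is 800 nM, with an expected range from 90 nM to 7000 nM.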

Compound 4, half-maximal inhibitory concentration: 27000 nM
Compound 4: the middle estimate sits 34-fold (1.53 log units) below what was measured, outside the stated range (above it).
By their numbers in this assay, from the lowest: compound 3; then compound 2; then compound 4.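

In this assay, 4-hydroxy-3,5-dimethoxyphenyl in place of 2,3,4-trimethoxyphenyl gives a 390-fold higher number from compound 3 to compound 4 (2.59 log units; beyond the scatter) and places the new group above both earlier groups with numbers. Its change from 2,5-dimethoxyphenyl gives a 3.7-fold higher number from compound 2 to compound 4 (0.57 log units; beyond the scatter) and is modest by comparison, so this position does not respond to every change with a step of the same size, and three oxygen atoms on the ring do not by themselves bring a low number. No measurement offered here explains why the number rises so sharply with this change.

The compounds shown leave open whether the rise follows the hydroxy group or the new arrangement of the methoxy groups, as both differ in this one exchange. From the compounds shown here alone, it also remains open how an amine or a carboxylic acid in place of the hydroxy group would read.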